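Sec-butyl to (furan-2-yl)methyl ester: expected cytotoxicity

The source may hold more compounds than are shown below. What is called first, only, known or untested is meant among the compounds shown, and "the series" means these compounds.

Compound 1 `CC(C)(C)OC(=O)C(O)Cn1cnc2c(N)ncnc21` in a functional assay on HeLa cells (Homo sapiens) for cytotoxicity (a higher number here means that more compound is tolerated, a lower number that less compound is tolerated), gives > 400 ug/mL, which is a limit of the assay.
Compound 2 `CCCOC(=O)C(O)Cn1cnc2c(N)ncnc21` gives > 400 ug/mL, again a limit.
Compound 3 `CCC(C)OC(=O)C(O)Cn1cnc2c(N)ncnc21` gives > 400 ug/mL, also a limit.

Compound 3 therefore sits at the limit of > 400 ug/mL in this assay, at which 3 of the 3 values shown sit, together with the other two compounds. The steps a step that the two limits leave unreadable from compound 1 to compound 3 and a step that the two limits leave unreadable from compound 2 to compound 3, like a step that the two limits leave unreadable from compound 1 to compound 2, cannot be read in size. Compound 4 `Nc1ncnc2c1ncn2CC(O)C(=O)OCc1ccco1` differs from compound 3 by (furan-2-yl)methyl in place of sec-butyl on an oxygen next to a carbonyl group. For the measured compounds named here, no measured step bears on this change with a readable size; the three limits show only that no ester so far has fallen short of the limit. No step beyond the scatter is expected, so the estimated step is a number no higher from compound 3 to compound 4 (the limit leaves the size open). Compound 4 is expected at 400 ug/mL, in the range 200 ug/mL to 800 ug/mL, most likely reported again as a limit.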

Compound 4, minimum cytotoxic concentration: 40 ug/mL
For compound 4 the middle estimate is 10-fold (1.00 log units) above the measured one; measured number outside the range, below it.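

In this assay, this ester position proves able to change the tolerated concentration: (furan-2-yl)methyl on this oxygen gives an at least 10-fold lower number from compound 3 to compound 4 (1.00 log units; beyond the scatter). The same change gives an at least 10-fold lower number from compound 2 to compound 4 (1.00 log units; beyond the scatter) and an at least 10-fold lower number from compound 1 to compound 4 (1.00 log units; beyond the scatter). The steps among the three saturated esters cannot be read, and compound 4 is the only one of the four with a value that is not a limit: the limit of > 400 ug/mL in this assay, at which 3 of the 4 values shown sit.

On these data alone, whether the furan ring as a whole or its oxygen goes with this result stays open. So does where a benzyl or (tetrahydrofuran-2-yl)methyl ester would stand.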